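A few compounds are considered here, and "the series" means these few. Any claim that something is new, unique, unknown or untested is made for them only; others in the source may bear on it.

Measured compounds:
Compound 1 `CCCCCCN1CCN(CCC(=O)Nc2nc3c(C)cccc3s2)CC1` — 158 nM
Compound 2 `Cc1cccc2sc(NC(=O)CCN3CCN(C4CCCCC4)CC3)nc12` — 233 nM

In an assay on membranes from liver for displacement of a labelled ligand from Sigma intracellular receptor 2 (Rattus norvegicus), read by scintillation counting, with a stated time of 120 min (on this read-out higher numbers stand for weaker inhibition and lower numbers for stronger inhibition), compound 2 gives 233 nM, and compound 1 gives 158 nM; the two sit within the scatter of each other, since a 1.5-fold higher number from compound 1 to compound 2 (0.17 log units; within the scatter). Compound 3 `Cc1cccc2sc(NC(=O)CCN3CCN(C4CCN(C)CC4)CC3)nc12` has not yet been measured. It differs from compound 2 in one place: 1-methylpiperidin-4-yl in place of cyclohexyl on an amine nitrogen in a ring. Within the data shown here, the only measured step also changes the group on that ring nitrogen, but it trades one all-carbon group for another, and the result was small, as a 1.5-fold higher number from compound 1 to compound 2 (0.17 log units; within the scatter) shows. Among the measured compounds shown here, no measured step puts a ring nitrogen into this position, so there is no direct precedent. A modest weakening is expected for compound 3, meaning a 2.1-fold higher number from compound 2 to compound 3 (0.33 log units; beyond the scatter), with wide uncertainty. The estimate for compound 3 is 500 nM, with a range of 150 nM to 2000 nM.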

Compound 3, inhibition constant: 3600 nM
Estimate against measurement, compound 3: 7.2-fold (0.86 log units) below, and the stated range ends below it.
By their numbers in this assay, from the lowest: compounds 1 and 2 (each within the scatter of the next); then compound 3.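

In this assay, putting 1-methylpiperidin-4-yl in place of cyclohexyl on this ring nitrogen gives a large loss of inhibition (a 15-fold higher number from compound 2 to compound 3 (1.19 log units; beyond the scatter)), and putting it in place of hexyl gives a large loss as well (a 23-fold higher number from compound 1 to compound 3 (1.36 log units; beyond the scatter)). This position therefore tolerates a change between the two all-carbon groups, which sit within the scatter of each other, but not this change to a group with a nitrogen in its ring. No measurement at hand accounts for the size of this loss.

The compounds shown leave open whether the loss goes with the ring nitrogen itself or with the methyl on it. A piperidin-4-yl without the methyl, or a tetrahydropyran-4-yl with an oxygen in place of that ring nitrogen, would help to separate these two possibilities.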